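The compounds below may be only part of what the source reports. "The series", "measured", "known", "first", "only" and "open" are said of these compounds alone.

Compound 1 `FC(F)(F)c1c(CN2CCC(c3ccccc3Cl)CC2)ccn2c(CC3CC3)nnc12`: 328%
Compound 2 `Fc1ccc(OC2CCN(Cc3ccn4c(CC5CC5)nnc4c3C(F)(F)F)CC2)c(F)c1`: 272%
Compound 3 `Fc1ccc([C@H]2CC[C@@H](NCc3ccn4c(CC5CC5)nnc4c3C(F)(F)F)CC2)c(F)c1`: 279%

In an assay on CHO cells for positive allosteric modulation of metabotropic glutamate receptor 2 (Homo sapiens), read by scintillation counting, with a stated time of 30 min (on this read-out higher numbers stand for larger maximal responses and lower numbers for smaller maximal responses), compound 3 reaches 279%, the second highest of the three numbers. Compound 2 is near it with 272%, within the scatter, while compound 1 stands higher with 328%, beyond the scatter. Compound 4 `Fc1ccc([C@H]2CC[C@H](NCc3ccn4c(CC5CC5)nnc4c3C(F)(F)F)CC2)c(F)c1` is not yet measured. How it differs from compound 3: the two compounds have the same atoms and bonds and differ only in configuration as drawn: 2 of 2 stereo elements differ (all stereocentres are inverted: mirror images); a stereocentre at a saturated ring carbon is drawn s in compound 3 and r in compound 4; a stereocentre at a saturated ring carbon is drawn s in compound 3 and r in compound 4. Going by the values given here, the only measured step, a number 56 percentage points lower from compound 1 to compound 2 (beyond the scatter), swaps one group for another rather than inverting configuration, so no measured step bears on this change. With nothing to show that a mirror image shifts the response, the expected step of a number 14 percentage points lower from compound 3 to compound 4 (beyond the scatter) is held within the scatter, in no particular direction, though the range is kept wide. Compound 4 is therefore expected to give 265%, between 180% and 330%.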

Compound 4, largest response reached (Emax), in percent of the reference or control that the assay uses: 264%
Beside the measured number, compound 4's estimate is 1 percentage points above it, and the stated range covers the measured number.
By their numbers in this assay, from the lowest: compounds 4, 2 and 3 (each within the scatter of the next, the first and the last beyond it); then compound 1.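

In this assay, going by these compounds alone, configuration alone is now seen to move the response, a kind of change the earlier compounds could not show: a number 15 percentage points lower from compound 3 to compound 4 (beyond the scatter). The step is modest, but no group changes here, so it can be assigned to configuration alone, because of what separates this pair: the fact that compounds 3 and 4 differ only in the configuration as drawn.

Which of the two arrangements gives the larger response with other groups remains open. So does whether the step would persist if a methoxy group or a nitrile replaced the 2,4-difluorophenyl group.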